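Methyl on the sulfonyl aryl ring, trifluoromethyl analogue

This account rests on a few compounds, and the source may have more. Where it says the series, first, only, none or still open, it means among the compounds named here.

Compound 1 `O=C1/C(=C/c2ccncc2)CN(S(=O)(=O)c2ccccc2)C/C1=C\c1ccccc1F` is the reference point. In a functional assay on QGY-7703 cells (Homo sapiens) for cytotoxicity, read by MTT assay, with a stated time of 24 h (on this read-out higher numbers stand for weaker inhibition and lower numbers for stronger inhibition), compound 1 gives 8400 nM. Compound 2 `Cc1ccc(S(=O)(=O)N2C/C(=C\c3ccncc3)C(=O)/C(=C/c3ccccc3F)C2)cc1` carries the change (methyl in place of hydrogen on an aromatic carbon). In this assay compound 2 reports only a limit of the assay, > 20000 nM, namely (the limit of > 20000 nM in this assay, at which 1 of the 3 values shown sits). The step is an at least 2.3-fold higher number from compound 1 to compound 2 (0.37 log units; beyond the scatter).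

Compound 3 `O=C1/C(=C/c2ccncc2)CN(S(=O)(=O)c2ccccc2)C/C1=C\c1ccccc1C(F)(F)F` differs from compound 1 by trifluoromethyl in place of fluoro on an aromatic carbon, which is also how the core of compound 3 differs from the core of compound 1. In this assay compound 3 gives 6210 nM, and the step from compound 1 is a 1.4-fold lower number from compound 1 to compound 3 (0.13 log units; within the scatter).

Compound 4 `Cc1ccc(S(=O)(=O)N2C/C(=C\c3ccncc3)C(=O)/C(=C/c3ccccc3C(F)(F)F)C2)cc1` has not yet been measured. It differs from compound 3 by methyl in place of hydrogen on an aromatic carbon, the same change as from compound 1 to compound 2, with the place described in the same words in both cases.

For compound 4 a step of a 2.6-fold higher number from compound 3 to compound 4 (0.41 log units; beyond the scatter) is expected because the same change gave an at least 2.3-fold higher number from compound 1 to compound 2 (0.37 log units; beyond the scatter), where the second value was a limit, so the true size of that step is not known and the expectation is wide. Compound 4 is accordingly estimated at 16000 nM, with a range from 6000 nM to 45000 nM.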

Compound 4, half-maximal inhibitory concentration: 5090 nM
Estimate against measurement, compound 4: 3.1-fold (0.50 log units) above, and the stated range ends above it.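

On the trifluoromethyl side, the methyl change gives a 1.2-fold lower number from compound 3 to compound 4 (0.09 log units; within the scatter), so in this assay it does not carry over from the fluoro pair: the same change on two cores in this assay, an at least 2.3-fold higher number (0.37 log units; beyond the scatter) from compound 1 to compound 2 and a 1.2-fold lower number (0.09 log units; within the scatter) from compound 3 to compound 4, at least 2.9-fold (0.46 log units) apart, beyond the scatter of two such steps.

Read the other way, trifluoromethyl in place of fluoro gives an at least 3.9-fold lower number from compound 2 to compound 4 (0.59 log units; beyond the scatter), and this step also differs from its counterpart on the phenylsulfonyl compounds: the same change on two cores in this assay, a 1.4-fold lower number (0.13 log units; within the scatter) from compound 1 to compound 3 and an at least 3.9-fold lower number (0.59 log units; beyond the scatter) from compound 2 to compound 4, at least 2.9-fold (0.46 log units) apart, beyond the scatter of two such steps.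

From the compounds shown here alone, for compound 2, > 20000 nM is a limit of the assay, so the true size of both gaps stays unknown, and these four compounds show that the two changes do not add independently here, not what causes this.

Open, going by these compounds, is whether a chloro or methoxy group in place of the fluoro or trifluoromethyl would side with the fluoro pair or the trifluoromethyl pair under the methyl change. Also open, on these data alone, is whether a methoxy group or an amine in place of the methyl on the sulfonyl phenyl would follow compound 2 or compound 4.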